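The compounds below may be only part of what the source reports. "The series", "measured", "known", "first", "only" and "open" are said of these compounds alone.

Measured compounds:
compound 1, `CCCCN1CCC(C(=O)Nc2ccc(CNc3nc(N(C)C)nc4cc(C)ccc34)cc2)CC1`, in a functional assay on SV5A8 cells (Homo sapiens) for cytotoxicity (a higher number here means a weaker inhibitor, a lower number a stronger inhibitor), gives > 10500 nM, which is a limit of the assay and not a number.
compound 2, `Cc1ccc2c(NCc3ccc(NC(=O)C4CCN(Cc5ccccc5)CC4)cc3)nc(N3CCC(N4CCCC4)CC3)nc2c1`, in this assay gives > 8090 nM, likewise a limit and not a number.

Both compounds share the same core and neither gives a measurable half-maximal inhibitory concentration. Compound 2 stands at the limit in this assay (the limit of > 8090 nM in this assay, at which 1 of the 2 values shown sits). Compound 1 stands at its own limit (the limit of > 10500 nM in this assay, at which 1 of the 2 values shown sits). Among the compounds with values here, the two limits give no order between the compounds and no step can be counted from them.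

Compound 3, `Cc1ccc2c(NCc3ccc(NC(=O)C4CCN(Cc5ccccc5)CC4)cc3)nc(N3CCN(C)CC3)nc2c1`, differs from compound 2 in one place: 4-methylpiperazin-1-yl in place of 4-(pyrrolidin-1-yl)piperidin-1-yl on an aromatic carbon. Within the data shown here, no measured pair in this set shows what this change does. With compound 2 already at a limit, the plain expectation is that compound 3 also fails to reach a measurable value. The step that the limit leaves unreadable from compound 2 to compound 3 is estimated as none beyond the usual scatter. Compound 3 is expected at 15000 nM in this assay, with a range from 5000 nM to 50000 nM, and most likely it is reported only as a limit again.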

Compound 3, half-maximal inhibitory concentration: > 17700 nM
Compound 3 ended at the assay's limit; the forecaster's own chance of this, stated with the estimate: 80%; middle value at least 1.1-fold (0.07 log units) away from the limit.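

In this assay compound 3 gives > 17700 nM, a limit of the assay and not a number. Compound 2 also stands at a limit of the assay, so no step can be read between compound 2 and compound 3. The compounds shown leave open whether any of them has a measurable half-maximal inhibitory concentration, and what size of step 4-methylpiperazin-1-yl in place of 4-(pyrrolidin-1-yl)piperidin-1-yl brings.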